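Swapping the Amide Ring Partner in a Histamine Receptor Series

The compounds below may be only part of what the source reports. "The series", "measured", "known", "first", "only" and "open" are said of these compounds alone.

This piece looks at a small set of amides measured in an assay on CHO cells for displacement of a labelled ligand from histamine receptor H3 (Macaca mulatta); on this read-out lower numbers stand for stronger inhibition and higher numbers for weaker inhibition. Compound 1 `CC1CCCN1C1CCN(c2ccc(NC(=O)C3CCCO3)cc2)C1` gives 8.7 nM in this assay. Compound 2 `Cc1cc(N2CC[C@H](N3CCC[C@@H]3C)C2)ccc1NC(=O)C1C(C)(C)C1(C)C` gives 0.55 nM, and compound 3 `Cc1cc(N2CCC(N3CCCC3C)C2)ccc1NC(=O)C1CC2CCC1C2` gives 19.9 nM. Among these three numbers compound 2 has the lowest, and its gaps to compound 1 and to compound 3 are both beyond the usual scatter, so compound 2 is the most potent of the three.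

Compound 4 `Cc1cc(N2CC[C@H](N3CCC[C@@H]3C)C2)ccc1NC(=O)C1CCCO1` has not yet been measured. It keeps the core of compound 2 and changes only the group on the carbonyl carbon: oxolan-2-yl in place of 2,2,3,3-tetramethylcyclopropyl on a carbonyl carbon. Within the data shown here, no direct step between two measured compounds covers this change. Still, compound 1 carries oxolan-2-yl on its carbonyl carbon too, though on a core that is not the same, and gives 8.7 nM; compound 2 gives 0.55 nM. That gap hints that the change may cost some binding. Compound 4 is therefore estimated at 4 nM, with a likely range from 1 nM to 15 nM. The expected step is a 7.3-fold higher number from compound 2 to compound 4 (0.86 log units; beyond the scatter), toward weaker inhibition.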

Compound 4, inhibition constant: 7.33 nM
Compound 4: the middle estimate sits 1.8-fold (0.26 log units) below what was measured; low and high end bracket the measured number.
By their numbers in this assay, from the lowest: compound 2; then compounds 4 and 1 (each within the scatter of the next); then compound 3.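

On the shared core, the group on the carbonyl carbon has a large influence in this assay: oxolan-2-yl in place of 2,2,3,3-tetramethylcyclopropyl gives a 13-fold higher number from compound 2 to compound 4 (1.12 log units; beyond the scatter) and so weakens inhibition. Among these compounds, this is the first reading of this change with everything else held constant, and it shows that this position does not accept these two rings equally. The data give no measured explanation for the loss of binding.

Going by these compounds, the change replaces an all-carbon ring bearing methyl groups with an oxygen-containing ring, so it remains open which of these differences matters more. Cyclopentyl or plain cyclopropyl on the same carbonyl carbon would help separate the ring oxygen from the methyl groups, and whether the step carries over to other cores is also unresolved.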